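Trading a Chain Hydroxy for Trifluoromethyl

The source may report more compounds than this note shows. Statements on the series, on what has been measured and on what is new or still open speak of the compounds shown alone.

In a functional assay on HT-29 cells (Homo sapiens) for inhibition, read by luminescence and CellTiter-Glo, with a stated time of 24 h (on this read-out lower numbers stand for an effect already at smaller amounts and higher numbers for an effect only at larger amounts of compound), the measured compounds stand as follows:
compound 1 `CCCCn1nc(C(=O)N[C@H]2COc3ccccc3N(C)C2=S)nc1Cc1ccccc1` gives 510 nM
compound 2 `CC(C)n1nc(C(=O)N[C@H]2COc3ccccc3N(C)C2=S)nc1Cc1ccccc1` gives 360 nM
compound 3 `CN1C(=S)[C@@H](NC(=O)c2nc(Cc3ccccc3)n(CCCO)n2)COc2ccccc21` gives 209 nM

Compound 3 stands firmly apart from only one of the other two. The numbers show a 2.4-fold lower number from compound 1 to compound 3 (0.39 log units; beyond the scatter) and, for the other pair, a 1.7-fold lower number from compound 2 to compound 3 (0.24 log units; within the scatter) in this assay.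

The unmeasured compound 4 `CN1C(=S)[C@@H](NC(=O)c2nc(Cc3ccccc3)n(CCC(F)(F)F)n2)COc2ccccc21` differs from compound 3 at one place (trifluoromethyl in place of hydroxymethyl on a saturated chain carbon, two bonds along the chain from an aromatic nitrogen). Cut one bond further out, 3-hydroxypropyl becomes 3,3,3-trifluoropropyl.

Going by the values given here, no measured pair makes this exact swap, so the evidence is indirect. Like compound 4, compound 1 and compound 2 have no hydroxy on this chain. Among the compounds with values here, the closest guide is compound 1, where hydroxy in place of methyl gave a 2.4-fold lower number from compound 1 to compound 3 (0.39 log units; beyond the scatter) as the only step beyond the scatter. Compound 2 offers weaker support, with a 1.7-fold lower number from compound 2 to compound 3 (0.24 log units; within the scatter) as its step. Trifluoromethyl is not methyl, however, so only part of that difference is expected to return.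

The expected change is a small move toward a higher number, estimated as a 1.4-fold higher number from compound 3 to compound 4 (0.16 log units; within the scatter) and so not clearly beyond the scatter. For compound 4 the estimated value is 300 nM, with an expected range from 120 nM to 700 nM.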

Compound 4, half-maximal effective concentration: 1550 nM
The estimate for compound 4 lay 5.2-fold (0.71 log units) below the measured number; measured number outside the range, above it.
By their numbers in this assay, from the lowest: compounds 3, 2 and 1 (each within the scatter of the next, the first and the last beyond it); then compound 4.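

In this assay, going by these compounds alone, trifluoromethyl at the end of this chain gives the largest step seen at this position so far, a 7.4-fold higher number from compound 3 to compound 4 (0.87 log units; beyond the scatter), and it also separates compound 4 from both chains that carry no hydroxy, with a 4.3-fold higher number from compound 2 to compound 4 (0.63 log units; beyond the scatter) and a 3.0-fold higher number from compound 1 to compound 4 (0.48 log units; beyond the scatter). Losing the hydroxy therefore cannot be the whole story: compound 1 and compound 2 lack it too, yet both have clearly lower numbers than compound 4, so the position responds to what replaces the hydroxy and not only to its absence. Within the data shown here, nothing available here explains why this one group raises the number so far.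

As far as these compounds go, what remains open is how much of the rise belongs to the three fluorines and how much to the loss of the hydroxy, which a methoxy group at the same chain end would help to separate. From the compounds shown here alone, it is also open how an amine or a carboxylic acid would fare in that place, and whether a shorter chain such as 2-hydroxyethyl or 2,2,2-trifluoroethyl would show the same gap.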